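The source may report more compounds than this note shows. Statements on the series, on what has been measured and on what is new or still open speak of the compounds shown alone.

Working notes on the series. The shared core is that of compound 2 `O=C(CSc1nnc(-c2ccncc2)n1-c1ccccc1)N/N=C/c1ccccc1`. Among the measured compounds shown here, in a functional assay on MCF7 cells (Homo sapiens) for inhibition, read by MTT assay, with a stated time of 48 h (on this read-out lower numbers stand for stronger inhibition and higher numbers for weaker inhibition), compound 2 gives 23600 nM, the only numerical value available here. Compound 1 `O=[N+]([O-])c1ccccc1CSc1nnc(-c2ccncc2)n1-c1ccccc1` reaches only a limit: in this assay compound 1 gives > 50000 nM, a limit of the assay and not a number, as recorded in the limit of > 50000 nM in this assay, at which 1 of the 2 values shown sits. Compound 3 `O=C(CSc1nnc(-c2ccncc2)n1-c1ccccc1)N/N=C/c1ccc(O)cc1` differs from compound 2 by hydroxy in place of hydrogen on an aromatic carbon. For the measured compounds named here, no step between measured compounds is available, so the estimated change is small, close to the scatter, as a 1.3-fold lower number from compound 2 to compound 3 (0.12 log units; within the scatter). For compound 3 the expected value is 18000 nM, between 6000 nM and 55000 nM.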

Compound 3, half-maximal inhibitory concentration: > 50000 nM
Compound 3 ended at the assay's limit (the forecaster's own chance of this, stated with the estimate: 25%); middle value at least 2.7-fold (0.44 log units) from the limit.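

Among the compounds shown here, the change from phenyl to 4-hydroxyphenyl gives the first readable step, an at least 2.1-fold higher number from compound 2 to compound 3 (0.32 log units; beyond the scatter), in this assay. Compound 3 gives > 50000 nM, which is a limit of the assay and not a number, so this step has a minimum size but no upper bound. Only compound 2 retains a numerical value: the limit of > 50000 nM in this assay, at which 2 of the 3 values shown sit.

Going by these compounds, whether a methoxy group, an amine or a carboxylic acid at this same position would stay within the assay's range remains open.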